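The source may hold more compounds than are shown below. What is called first, only, known or untested is meant among the compounds shown, and "the series" means these compounds.

Measured so far

Compound 1 `O=C(Nc1ccc(Sc2nc3ccccc3s2)cc1)c1cc(Br)cc(Br)c1` — in an assay on isolated protein for inhibition of thiosulfate sulfurtransferase (Homo sapiens), with a stated time of 60 min, in the absence of a further agent (a lower number here means a stronger inhibitor, a higher number a weaker inhibitor), compound 1 gives > 100000 nM, which is a limit of the assay and not a number.
Compound 2 `COc1c(Br)cccc1C(=O)Nc1ccc(Sc2nc3ccccc3s2)cc1` — in this assay compound 2 gives > 100000 nM, again a limit of the assay and not a number.

Where compound 2 stands: only a limit is known for compound 2 in this assay, and no number. Within the data shown here, the single measured step, a step that the two limits leave unreadable from compound 1 to compound 2, cannot be read, since (the limit of > 100000 nM in this assay, at which 2 of the 2 values shown sit). Among the measured compounds shown here, nothing so far separates any two compounds.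

Compound 3 `COc1c(Br)cccc1C(=O)Nc1ccc(Sc2nc3ccccc3s2)c(Cl)c1` is compound 2 with chloro in place of hydrogen on an aromatic carbon, ortho to a large group and meta to a large group. For the measured compounds named here, no measured step bears on this change; the one step that exists is unreadable, so the size expected in this assay can only be stated as no step beyond the scatter, in either direction. Compound 3 is expected to sit at about 150000 nM, within 30000 nM to 500000 nM. The step this estimate implies, a step that the limit leaves unreadable from compound 2 to compound 3, is expected to stay within the scatter, with a limit the most likely report.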

Compound 3, half-maximal inhibitory concentration: > 100000 nM
Compound 3: a limit, no number (the forecaster's own chance of this, stated with the estimate: 80%); the middle value lies beyond the limit too.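

Compound 3, like compound 2, gives only a limit of the assay and no number in this assay, so the step from hydrogen to chloro cannot be read: the limit of > 100000 nM in this assay, at which 3 of the 3 values shown sit.

The compounds shown leave open whether any change to the shared core gives a measurable value in this assay, and which change that would be.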